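Dichlorophenyl analogue of a spiro triazine antiproliferative

The source may report more compounds than this note shows. Statements on the series, on what has been measured and on what is new or still open speak of the compounds shown alone.

Three compounds sharing one core were tested in a functional assay on MDA-MB-231 cells (Homo sapiens) for antiproliferative activity, read by MTT assay, with a stated time of 72 h; a higher number here means a weaker inhibitor, a lower number a stronger inhibitor. Compound 1 `NC1=NC2(CCSCC2)N(OCCCOc2ccc(Br)cc2)C(N)=N1` gives 440 nM, compound 2 `COc1ccc(OCCCON2C(N)=NC(N)=NC23CCSCC3)cc1` gives 350 nM, and compound 3 `NC1=NC2(CCSCC2)N(OCCCOc2cccc(Br)c2)C(N)=N1` gives 60 nM, the lowest number of the three; both of its steps to the others lie beyond the scatter, so compound 3 is the most potent of the set. The step of a 1.3-fold lower number from compound 1 to compound 2 (0.10 log units; within the scatter) is within the scatter, whereas a 7.3-fold lower number from compound 1 to compound 3 (0.87 log units; beyond the scatter) and a 5.8-fold lower number from compound 2 to compound 3 (0.77 log units; beyond the scatter) are modest but real.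

Compound 4 `NC1=NC2(CCSCC2)N(OCCCOc2ccc(Cl)c(Cl)c2)C(N)=N1` differs from compound 3 in one place: 3,4-dichlorophenyl in place of 3-bromophenyl on an oxygen on a saturated carbon. Among the measured compounds shown here, no measured step involves a 3,4-dichlorophenyl. The 3,4-dichlorophenyl shares features with both the 3-bromophenyl of compound 3 and the 4-bromophenyl of compound 1, and the step of a 7.3-fold lower number from compound 1 to compound 3 (0.87 log units; beyond the scatter) shows the 3-bromophenyl pattern to be the more favourable. A small loss is therefore expected, no larger than the scatter or slightly beyond it, giving a 2.0-fold higher number from compound 3 to compound 4 (0.30 log units; within the scatter). Compound 4 is expected to give 120 nM, within a range from 40 nM to 400 nM.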

Compound 4, half-maximal inhibitory concentration: 10 nM
Beside the measured number, compound 4's estimate is 12-fold (1.08 log units) above it, outside the stated range (below it).
By their numbers in this assay, from the lowest: compound 4; then compound 3; then compounds 2 and 1 (each within the scatter of the next).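

In this assay, among the compounds shown here, the 3,4-dichlorophenyl on an oxygen on a saturated carbon is the first group to improve on the 3-bromophenyl (here a 6.0-fold lower number from compound 3 to compound 4 (0.78 log units; beyond the scatter)), which makes compound 4 the most potent of the four. The gaps to the other two analogues are wider still, both large (a 35-fold lower number from compound 2 to compound 4 (1.54 log units; beyond the scatter); a 44-fold lower number from compound 1 to compound 4 (1.64 log units; beyond the scatter)), so this position can give much more than the change from a 4-bromophenyl to a 3-bromophenyl had shown. No evidence is available to explain this gain.

The compounds shown leave open whether a phenyl carrying a single chlorine would hold the gain or whether both chlorines are needed. They also leave open how a phenyl carrying a trifluoromethyl or two methoxy groups would compare at this position.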